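A carboxyphenyl sulfonamide replaces the methylsulfonyl of compound 1

The source may hold more compounds than are shown below. What is called first, only, known or untested is meant among the compounds shown, and "the series" means these compounds.

All four compounds share one core, and differ only in the group attached to the amine nitrogen of the side chain. Compound 1 `CS(=O)(=O)N[C@@H](CNC(=O)c1ccc2c(c1)C(=O)N(CCC1CCNCC1)C2)C(=O)O` carries a methylsulfonyl there; in a functional assay for inhibition, with Homo sapiens as the target (on this read-out higher numbers stand for weaker inhibition and lower numbers for stronger inhibition), compound 1 gives 14 nM. Compound 3 `O=C(NCc1ccccc1)N[C@@H](CNC(=O)c1ccc2c(c1)C(=O)N(CCC1CCNCC1)C2)C(=O)O` carries a benzylcarbamoyl instead and gives 10 nM; the step of a 1.4-fold lower number from compound 1 to compound 3 (0.15 log units; within the scatter) shows that the two lie within the scatter of each other, so no order between them can be claimed. Compound 2 `CCCCS(=O)(=O)N[C@@H](CNC(=O)c1ccc2c(c1)C(=O)N(CCC1CCNCC1)C2)C(=O)O`, with a butylsulfonyl, gives 14 nM; 9 nM (2 entries); its several entries, (the several entries of compound 2 in this assay, 14 nM; 9 nM (2 entries)), all lie in the same region as compound 1 and compound 3.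

Compound 4 `O=C(NC[C@H](NS(=O)(=O)c1ccccc1C(=O)O)C(=O)O)c1ccc2c(c1)C(=O)N(CCC1CCNCC1)C2` arises from compound 1 by the change (2-carboxyphenyl in place of methyl on a sulfonyl sulfur). Going by the values given here, no measured step covers this exact change; what is known is only that methylsulfonyl, butylsulfonyl and benzylcarbamoyl all give numbers close together. On that basis the expected step of a 1.2-fold lower number from compound 1 to compound 4 (0.07 log units; within the scatter) is none beyond the scatter. Compound 4 is therefore estimated at 12 nM, with a range from 4 nM to 40 nM.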

Compound 4, half-maximal inhibitory concentration: 15 nM
Compound 4: middle estimate off by 1.3-fold (0.10 log units), on the low side; the measured number falls inside the stated range.
By their numbers in this assay, from the lowest: compounds 3, 1 and 4 (each within the scatter of the next).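

In this assay, the sulfonyl sulfur accepts far more than a small alkyl chain: 2-carboxyphenyl in place of methyl gives a 1.1-fold higher number from compound 1 to compound 4 (0.03 log units; within the scatter), and the comparison with the urea-type side chain gives a 1.5-fold higher number from compound 3 to compound 4 (0.18 log units; within the scatter). Going by these compounds alone, the earlier compounds covered only methylsulfonyl, butylsulfonyl and benzylcarbamoyl, so this is the first sign that a six-membered aromatic ring carrying a carboxylic acid can sit here and leave the number in the same region. Both steps are no wider than the spread among repeat entries for a single compound: the several entries of compound 2 in this assay, 14 nM; 9 nM (2 entries)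

A plain phenylsulfonyl group would show whether the ring and the carboxylic acid each matter on their own. From the compounds shown here alone, it also remains open how an amine in place of that carboxylic acid would read, and whether any group at this position can move the number beyond the scatter.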